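The source may hold more compounds than are shown below. What is called first, only, known or untested is meant among the compounds shown, and "the series" means these compounds.

Measured so far:
Compound 1 `Cc1ccccc1-c1nn(-c2cc(F)ccc2F)cc1CNCCN1CCN(C)CC1`, in an ADME assay on Huh-7 cells (Homo sapiens) for cytotoxicity (on this read-out higher numbers stand for lower toxicity in this test and lower numbers for higher toxicity in this test), compound 1 gives > 20000 nM, which is a limit of the assay.
Compound 2 `CCN(CC)CCCNCc1cn(-c2ccc(F)cc2F)nc1-c1ccccc1C`, in this assay compound 2 gives > 20000 nM, also a limit.
Compound 3 `COc1ccc(-c2nn(-c3ccc(F)cc3F)cc2CNCCN2CCN(C)CC2)cc1`, in this assay compound 3 gives > 20000 nM, again a limit.

Compound 2 therefore stands nowhere in particular among the numbers shown: it sits at the limit of > 20000 nM in this assay, at which 3 of the 3 values shown sit, and no compound here has a value that separates it from the others. Compound 4 `Cc1ccccc1-c1nn(-c2ccc(F)cc2F)cc1CNCCN(C)C` has not been measured in this assay. It differs from compound 2 in one place: dimethylamino in place of (diethylamino)methyl on a saturated chain carbon, two bonds along the chain from an amine nitrogen, so that the chain ending in (3-(diethylamino)propyl)amino becomes one ending in (2-(dimethylamino)ethyl)amino. Among the compounds with values here, no measured pair here shows what such a change does in this assay, so the step is expected to be none beyond the scatter, in either direction. The estimate for compound 4 in this assay is 30000 nM, in the range 12000 nM to 100000 nM, which means an expected step that the limit leaves unreadable from compound 2 to compound 4 from the limit of compound 2, with a high chance that only a limit is reported again.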

Compound 4, half-maximal cytotoxic concentration: > 20000 nM
Compound 4: a limit, no number; the forecaster's own chance of this, stated with the estimate: 85%; the middle value is on the limit's open side.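

In this assay, within the data shown here, compound 4 gives a limit just as compound 2 does, so no step between compound 2 and compound 4 can be read. The compounds shown leave open whether any change among them alters cytotoxicity at all: all four values are limits, and none is a number.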